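This account rests on a few compounds, and the source may have more. Where it says the series, first, only, none or still open, it means among the compounds named here.

Measured so far:
compound 1 `Cn1cc(C2=C(c3nn(CCCn4ccnc4)c4ncccc34)C(=O)N(c3ccccc3)C2=O)c2ccccc21` – 1560 nM
compound 2 `Cn1cc(C2=C(c3nn(CCCO)c4ncccc34)C(=O)NC2=O)c2ccccc21` – > 100000 nM

Among the measured compounds shown here, in a functional assay on A549 cells (Homo sapiens) for antiproliferative activity, read by MTT assay, with a stated time of 48 h (on this read-out higher numbers stand for weaker inhibition and lower numbers for stronger inhibition), compound 1 gives 1560 nM, the only true number among the values shown. For compound 2 the read-out is a limit of the assay (the limit of > 100000 nM in this assay, at which 1 of the 2 values shown sits), not a number. Compound 3 `Cn1cc(C2=C(c3nn(CCCCn4ccnc4)c4ncccc34)C(=O)N(c3ccccc3)C2=O)c2ccccc21` has not been measured. It differs from compound 1 in one place: (1H-imidazol-1-yl)methyl in place of 1H-imidazol-1-yl on a saturated chain carbon, three bonds along the chain from an aromatic nitrogen. Seen one bond further out, the change reads 3-(1H-imidazol-1-yl)propyl to 4-(1H-imidazol-1-yl)butyl, and the step expected from it is a 1.0-fold higher number from compound 1 to compound 3 (0.01 log units; within the scatter), within the usual scatter. Compound 3 is therefore expected to give about 1600 nM, in a range of 600 nM to 4500 nM.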

Compound 3, half-maximal inhibitory concentration: 21700 nM
Compound 3: the middle estimate sits 14-fold (1.13 log units) below what was measured; the whole stated range lies below it.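

In this assay, lengthening the chain from 3-(1H-imidazol-1-yl)propyl to 4-(1H-imidazol-1-yl)butyl gives a 14-fold higher number from compound 1 to compound 3 (1.14 log units; beyond the scatter). This position on the saturated chain is therefore sensitive to chain length: with the imidazole ring itself unchanged and the rest of the molecule the same, this lengthening alone weakens inhibition beyond the scatter. Nothing in the data shown explains the loss. As far as these compounds go, whether a shorter 2-(1H-imidazol-1-yl)ethyl chain, or an amine in place of the imidazole on the propyl chain, would keep or improve inhibition stays open.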